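Amide substituent changes on the shared core

The source may report more compounds than this note shows. Statements on the series, on what has been measured and on what is new or still open speak of the compounds shown alone.

Compound 1 `CCn1c(C(=O)NCC#N)ccc1C(CC)(CC)c1ccc(OCCC(O)(CC)CC)c(C)c1` carries a cyanomethyl on the amide nitrogen of the shared core. In a functional assay on HepG2 cells (Homo sapiens) for antiproliferative activity, read by MTT assay, with a stated time of 48 h (on this read-out lower numbers stand for stronger inhibition and higher numbers for weaker inhibition), compound 1 gives only a limit, > 50000 nM. Compound 2 `CCC(C)C(NC(=O)c1ccc(C(CC)(CC)c2ccc(OCCC(O)(CC)CC)c(C)c2)n1CC)C(=O)OC` likewise gives only a limit in this assay, > 50000 nM. Compound 3 `CCC(C)C(CO)NC(=O)c1ccc(C(CC)(CC)c2ccc(OCCC(O)(CC)CC)c(C)c2)n1CC` also gives only a limit, > 50000 nM. The steps a step that the two limits leave unreadable from compound 1 to compound 2, a step that the two limits leave unreadable from compound 1 to compound 3 and a step that the two limits leave unreadable from compound 2 to compound 3 are accordingly unreadable, since every value sits at the limit of > 50000 nM in this assay, at which 3 of the 3 values shown sit. Compound 4 `CCn1c(C(=O)NC(CO)CCO)ccc1C(CC)(CC)c1ccc(OCCC(O)(CC)CC)c(C)c1` continues the series: 3-hydroxy-1-(hydroxymethyl)propyl in place of cyanomethyl on an amide-type nitrogen. The measured steps that bear on this change, all at the same amide nitrogen, give no readable size, and no shift beyond the scatter is expected in this assay. The step of a number no higher from compound 1 to compound 4 (the limit leaves the size open) is estimated as essentially none, with compound 4 expected to return a limit as well. For compound 4 the estimate is 50000 nM, between 20000 nM and 100000 nM.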

Compound 4, half-maximal inhibitory concentration: 24800 nM
Compound 4: the middle estimate sits 2.0-fold (0.30 log units) above what was measured, within the range that was stated.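

In this assay, going by these compounds alone, 3-hydroxy-1-(hydroxymethyl)propyl on the amide-type nitrogen gives the only measured number at this position, where the other groups return limits. The steps are an at least 2.0-fold lower number from compound 1 to compound 4 (0.30 log units; that floor lies within the scatter), an at least 2.0-fold lower number from compound 3 to compound 4 (0.30 log units; that floor lies within the scatter) and an at least 2.0-fold lower number from compound 2 to compound 4 (0.30 log units; that floor lies within the scatter); each is only a floor. Their true sizes stay open because the other compounds sit at a limit: the limit of > 50000 nM in this assay, at which 3 of the 4 values shown sit.

The compounds shown leave open whether a number at this position depends on the two hydroxyl groups. Also open, from the compounds shown here alone, is what an amine, a carboxylic acid or a longer hydroxyalkyl chain would give on this nitrogen.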